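The source may report more compounds than this note shows. Statements on the series, on what has been measured and on what is new or still open speak of the compounds shown alone.

Working notes on the series. Compound 1 `O=C(O)C1=Cc2ccccc2OC1(OCc1cc(-c2ccc(F)cc2)no1)C(F)(F)F` carries a free carboxylic acid, and in a functional assay on DU-145 cells (Homo sapiens) for inhibition, read by MTT assay, with a stated time of 24 h (on this read-out lower numbers stand for stronger inhibition and higher numbers for weaker inhibition), compound 1 gives 168000 nM. Compound 2 `CCOC(=O)C1=Cc2ccccc2OC1(OCc1cc(-c2ccc(OC)cc2)no1)C(F)(F)F` is the corresponding ethyl ester with a methoxyphenyl group. For compound 2 this assay reports only a limit, > 150000 nM. Compound 3 `CCCCCCCCn1cc(COC2(C(F)(F)F)Oc3ccccc3C=C2C(=O)OCC)nn1` bears an octyl group on an aromatic nitrogen. For compound 3 this assay likewise gives only a limit, > 150000 nM. Compound 3 thus stands at the limit of the measurement, where two of the three values shown sit (the limit of > 150000 nM in this assay, at which 2 of the 3 values shown sit), and compound 1 alone returns a number.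

Compound 4 `CCOC(=O)C1=Cc2ccccc2OC1(OCc1cn(-c2ccc([N+](=O)[O-])cc2)nn1)C(F)(F)F` differs from compound 3 by 4-nitrophenyl in place of octyl on an aromatic nitrogen. For the measured compounds named here, no measured pair isolates this change. In this assay no step beyond the scatter is expected in either direction, since two of the three values sit at the limit (the limit of > 150000 nM in this assay, at which 2 of the 3 values shown sit). For compound 4 the estimate is 180000 nM, within 60000 nM to 400000 nM, and most likely reported again as a limit. The expected step is a step that the limit leaves unreadable from compound 3 to compound 4.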

Compound 4, half-maximal inhibitory concentration: > 150000 nM
Compound 4: no number, only a limit (the forecaster's own chance of this, stated with the estimate: 65%); the middle value is on the limit's open side.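

No step can be read between compound 3 and compound 4, as both return only a limit in this assay: the limit of > 150000 nM in this assay, at which 3 of the 4 values shown sit.

The compounds shown leave open whether any group on that aromatic nitrogen brings an ethyl ester of this series to a measurable value.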